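Methyl on the chain carbon: compound 2 to compound 3

The source may report more compounds than this note shows. Statements on the series, on what has been measured and on what is new or still open speak of the compounds shown alone.

- compound 1 `COC(=O)N(C)C(C)C#CCn1ccnc1` gives 8 mg/kg (a number)
- compound 2 `CCOC(=O)N(C)CC#CCn1ccnc1` gives > 100 mg/kg (a limit)

Both compounds were read in a functional assay on the whole organism for agonist activity, with Mus musculus as the target (on this read-out higher numbers stand for an effect only at larger amounts of compound and lower numbers for an effect already at smaller amounts), and only compound 1 returns a number there. For compound 2 the read-out is a limit of the assay and not a number (> 100 mg/kg). As far as these compounds go, the position of compound 2 is thus the limit of > 100 mg/kg in this assay, at which 1 of the 2 values shown sits, and the true dose stays open.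

Compound 3 `CCOC(=O)N(C)C(C)C#CCn1ccnc1` comes from compound 2 by a single change: methyl in place of hydrogen on a saturated chain carbon bound to an amide-type nitrogen and a triple-bonded carbon. Among the compounds with values here, no measured pair isolates this change. Compound 1 carries a methyl at that place and gives 8 mg/kg in this assay, and this is the only support for the expectation. The expected shift is an at least 4.0-fold lower number from compound 2 to compound 3 (0.60 log units; beyond the scatter) in this assay, toward smaller doses and beyond the scatter, though another limit remains possible. For compound 3 the estimated dose is 25 mg/kg with an expected range of 6 mg/kg to 100 mg/kg in this assay as the working figure.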

Compound 3, dose for half-maximal effect: > 100 mg/kg
Compound 3: no number, only a limit; the forecaster's own chance of this, stated with the estimate: 25%; middle value at least 4.0-fold (0.60 log units) away from the limit.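

In this assay, methyl in place of hydrogen on a saturated chain carbon bound to an amide-type nitrogen and a triple-bonded carbon does not on its own yield a number: compound 3 remains at a limit of the assay, > 100 mg/kg. The step from compound 2 to compound 3 cannot be read, because both ends are limits: the limit of > 100 mg/kg in this assay, at which 2 of the 3 values shown sit. With the chain methyl present in both compounds, methyl in place of hydrogen on a saturated chain carbon bound to an oxygen next to a carbonyl group gives an at least 12-fold higher number from compound 1 to compound 3 (1.09 log units; beyond the scatter) in this assay, so the number for compound 1 depends on that end of the molecule as well, not on the chain methyl alone.

The size of any contribution from the chain methyl stays open, as no pair among the compounds shown has a number on both sides of that change. Also open, as far as these compounds go, is how a longer chain, such as propyl, on that oxygen would read in this assay, and whether any group larger than methyl there can return a number.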